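The source may report more compounds than this note shows. Statements on the series, on what has been measured and on what is new or still open speak of the compounds shown alone.

Among the compounds with values here, compound 3 `CCCCNc1nc(N)nc2c1CN(Cc1ccccn1)CC2` gives 0.07 uM in an assay on HEK293 cells for agonist activity at Toll-like receptor 8 (Homo sapiens), read by a luciferase reporter, with a stated time of 6 h (a higher number here means that more compound is needed for the effect, a lower number that less compound is needed), the lowest of the three numbers so far. Compound 1 `CCCCNc1nc(N)nc2c1CNCC2` gives 7.2 uM in this assay, and compound 2 `CCCCNc1nc(N)nc2c1CN(S(C)(=O)=O)CC2` gives 9.9 uM. The move to compound 4 `CCCCNc1nc(N)nc2c1CN(C(=O)C(C)C)CC2` is isopropylcarbonyl in place of (pyridin-2-yl)methyl on an amine nitrogen in a ring. The measured steps that bear on it run the other way: a 100-fold lower number from compound 1 to compound 3 (2.01 log units; beyond the scatter) and a 140-fold lower number from compound 2 to compound 3 (2.15 log units; beyond the scatter), both large, while a 1.4-fold higher number from compound 1 to compound 2 (0.14 log units; within the scatter) shows that hydrogen and methylsulfonyl on this nitrogen sit together. Isopropylcarbonyl, like methylsulfonyl, is not (pyridin-2-yl)methyl, so a large step upward in this assay is expected, back toward the numbers of compounds 1 and 2. Compound 4 is therefore estimated at 5 uM, with a range of 1 uM to 15 uM. The expected step is a 71-fold higher number from compound 3 to compound 4 (1.85 log units; beyond the scatter).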

Compound 4, minimum effective concentration: 1.6 uM
Beside the measured number, compound 4's estimate is 3.1-fold (0.49 log units) above it; the measured number falls inside the stated range.
By their numbers in this assay, from the lowest: compound 3; then compound 4; then compounds 1 and 2 (each within the scatter of the next).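

In this assay the amine nitrogen in a ring now shows a third level: a 4.5-fold lower number from compound 1 to compound 4 (0.65 log units; beyond the scatter) and a 6.2-fold lower number from compound 2 to compound 4 (0.79 log units; beyond the scatter) are both modest, so not every replacement of (pyridin-2-yl)methyl returns to the numbers of hydrogen and methylsulfonyl. Still, a 23-fold higher number from compound 3 to compound 4 (1.36 log units; beyond the scatter) remains large, so isopropylcarbonyl keeps only part of the gain seen with (pyridin-2-yl)methyl. On these data alone, whether a benzyl group would hold the low number of compound 3 stays open, as does the effect of a longer chain on the carbonyl. No measurement on hand accounts for the order of these groups.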